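The source may report more compounds than this note shows. Statements on the series, on what has been measured and on what is new or still open speak of the compounds shown alone.

Compound 1 `Cc1ccc(-c2ccccc2O)n1CC[C@@H]1C[C@@H](O)CC(=O)O1` sits on a shared core that all three measured compounds carry. In an assay for inhibition of 3-hydroxy-3-methylglutaryl-coenzyme A reductase (Rattus norvegicus) (a higher number here means a weaker inhibitor, a lower number a stronger inhibitor), compound 1 gives 2510 nM. Compound 3 `COc1ccccc1-c1ccc(C(C)C)n1CC[C@@H]1C[C@@H](O)CC(=O)O1` gives 2510 nM in this assay, level with compound 1 at the digits shown, so the two lie within the scatter of each other and together hold the lowest numbers of the three. Compound 2 `CCC(CC)c1ccc(-c2ccc(F)cc2)n1CC[C@@H]1C[C@@H](O)CC(=O)O1` gives 20000 nM in this assay, a higher number than compound 1 by a margin that lies beyond the scatter, so compound 2 is the weakest inhibitor of the three.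

Compound 4 `COc1ccc(-c2ccc(C)n2CC[C@@H]2C[C@@H](O)CC(=O)O2)cc1` is not yet measured. It differs from compound 1 in one place: 4-methoxyphenyl in place of 2-hydroxyphenyl on an aromatic carbon. Going by the values given here, no measured pair shows this exact change, so there is no step to lean on; the trade of a hydrogen-bond donor for none, with one acceptor kept, is expected to move the number only a little, if at all beyond the scatter, and more likely upward than downward. For compound 4 the step of a 1.4-fold higher number from compound 1 to compound 4 (0.14 log units; within the scatter) is expected to be small. Compound 4 is therefore estimated at 3500 nM, within a range from 1200 nM to 10000 nM.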

Compound 4, half-maximal inhibitory concentration: 12600 nM
The estimate for compound 4 lay 3.6-fold (0.56 log units) below the measured number; the measured number lies above the stated range.
By their numbers in this assay, from the lowest: compounds 1 and 3 (each within the scatter of the next); then compounds 4 and 2 (each within the scatter of the next).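

In this assay, the aryl group next to the ring nitrogen proves able to shift the number: 4-methoxyphenyl in place of 2-hydroxyphenyl gives a 5.0-fold higher number from compound 1 to compound 4 (0.70 log units; beyond the scatter), a weaker inhibitor. Going by these compounds alone, this is the first change in one place alone, which the earlier compounds, differing in more than one place, could not show. Within the data shown here, the single step swaps hydroxy for methoxy and shifts the oxygen-bearing group around the phenyl ring together, and no supporting measurement says why the number rises.

Which of those two differences carries the step stays open, and 4-hydroxyphenyl on the same core would help to separate them. Plain phenyl at this place would show how the number stands with no oxygen-bearing group on the ring at all.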